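The source may report more compounds than this note shows. Statements on the series, on what has been measured and on what is new or still open speak of the compounds shown alone.

Compound 1, `CCCCCc1cc2ccccc2nc1-c1cc(-c2ccccc2)no1`, was tested in a functional assay on COLO 205 cells (Homo sapiens) for inhibition, read by MTT assay, with a stated time of 24 h; on this read-out lower numbers stand for stronger inhibition and higher numbers for weaker inhibition. In this assay compound 1 gives > 100000 nM, which is a limit of the assay rather than a number.
Compound 2, `CCc1cc2ccccc2nc1-c1cc(-c2ccc(C)cc2)no1`. In this assay compound 2 gives > 100000 nM, again a limit.
Compound 3, `CCCc1cc2ccccc2nc1-c1cc(-c2ccc(C)cc2)no1`. In this assay compound 3 gives > 100000 nM, also a limit.

Compound 3 therefore stands at the ceiling of what this assay reports, and the other two measured compounds stand at the same ceiling. For the measured compounds named here, the one step that can be traced between measured compounds, a step that the two limits leave unreadable from compound 2 to compound 3, cannot be sized, since both ends are limits. The same holds across the whole set, as the limit of > 100000 nM in this assay, at which 3 of the 3 values shown sit, records.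

The unmeasured compound 4, `CCCCCc1cc2ccccc2nc1-c1cc(-c2ccc(C)cc2)no1`, differs from compound 3 by ethyl in place of hydrogen on a saturated chain carbon, three bonds along the chain from an aromatic carbon. Going by the values given here, no measured step bears on this change with a readable size; the only comparison available, from compound 2 to compound 3, is unreadable. Compound 1, which also carries a pentyl chain on the shared core, sits at the same limit. For compound 4 the expectation is therefore no resolvable inhibition in this assay, with the step that the limit leaves unreadable from compound 3 to compound 4 expected to be indistinguishable from none. The estimate for compound 4 is 150000 nM, expected to fall between 50000 nM and 500000 nM, most likely reported only as a limit.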

Compound 4, half-maximal inhibitory concentration: > 100000 nM
Compound 4: only a limit was reported; the forecaster's own chance of this, stated with the estimate: 85%; the middle value is on the limit's open side.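

In this assay compound 4 gives > 100000 nM, a limit of the assay and not a number. No step to it from compound 1, compound 2 or compound 3 can be read, as all the values shown are limits: the limit of > 100000 nM in this assay, at which 4 of the 4 values shown sit.

The compounds shown leave open whether any change on the shared core brings inhibition into a readable range.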